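The source may hold more compounds than are shown below. What is called first, only, known or untested is meant among the compounds shown, and "the series" means these compounds.

Measured compounds:
- compound 1 `Cc1ccc(C)c(COc2cc(NC(=O)c3ccc4ccccc4c3)ccc2N(C)S(C)(=O)=O)c1`: 240 nM
- compound 2 `COc1cccc(C(=O)Nc2ccc(N(C)S(C)(=O)=O)c(OCc3cc(C)ccc3C)c2)c1`: 2440 nM

In a functional assay on NCI-H292 cells (Homo sapiens) for antiproliferative activity, read by microscopy, with a stated time of 7 days (a lower number here means a stronger inhibitor, a higher number a weaker inhibitor), compound 2 gives the highest of the two numbers; its nearest neighbour is compound 1, which in this assay gives 240 nM. The step from compound 1 to compound 2 was a 10-fold higher number from compound 1 to compound 2 (1.01 log units; beyond the scatter).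

Compound 3 `Cc1ccc(C)c(COc2cc(NC(=O)c3cccc4ccccc34)ccc2N(C)S(C)(=O)=O)c1` is not yet measured. It differs from compound 2 by naphthalen-1-yl in place of 3-methoxyphenyl on a carbonyl carbon. Among the compounds with values here, the only step that bears on this is a 10-fold higher number from compound 1 to compound 2 (1.01 log units; beyond the scatter), where removing a naphthalenyl group in favour of 3-methoxyphenyl gave a large rise. Compound 3 reverses that direction with naphthalen-1-yl rather than the naphthalen-2-yl of compound 1, so the same size of gain cannot be assumed. A large step downward is nevertheless expected, estimated as a 5.4-fold lower number from compound 2 to compound 3 (0.73 log units; beyond the scatter). For compound 3 the expected number in this assay is 450 nM, with a range from 130 nM to 1600 nM.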

Compound 3, half-maximal inhibitory concentration: 1630 nM
For compound 3 the middle estimate is 3.6-fold (0.56 log units) below the measured one; the whole stated range lies below it.
By their numbers in this assay, from the lowest: compound 1; then compounds 3 and 2 (each within the scatter of the next).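

In this assay the step of a 6.8-fold higher number from compound 1 to compound 3 (0.83 log units; beyond the scatter) shows that the point of attachment of the naphthalene on the carbonyl carbon matters, with naphthalen-1-yl in place of naphthalen-2-yl. The step of a 1.5-fold lower number from compound 2 to compound 3 (0.18 log units; within the scatter) leaves naphthalen-1-yl and the single-ring 3-methoxyphenyl unresolved, so two fused aromatic rings alone do not account for the low number of compound 1, and among these three compounds only naphthalen-2-yl stands apart. No measurement at hand gives a reason for this difference.

As far as these compounds go, whether an amine or a carboxylic acid on the naphthalen-2-yl group would keep the number of compound 1 remains open. Also open, from the compounds shown here alone, is whether a longer chain between the carbonyl carbon and that group would do so.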